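The compounds below may be only part of what the source reports. "The series", "measured", "known", "first", "only" and "open" are said of these compounds alone.

Measured in a functional assay on Raji cells (Homo sapiens) for antiproliferative activity, read by MTT assay, with a stated time of 48 h; a lower number here means a stronger inhibitor, a higher number a weaker inhibitor:
Compound 1 `N#Cc1nc2c(-c3nc4ccccc4[nH]3)c(N)n(CCN3CCCC3)c2nc1C#N`: > 50000 nM, a limit.
Compound 2 `CCCn1c(N)c(-c2nc3ccccc3[nH]2)c2nc(C#N)c(C#N)nc21`: > 50000 nM, a limit.
Compound 3 `CN(C)CCCn1c(N)c(-c2nc3ccccc3[nH]2)c2nc(C#N)c(C#N)nc21`: 1230 nM.

Compound 3 is the only one of the three with an actual number. Compound 1 and compound 2 rest on (the limit of > 50000 nM in this assay, at which 2 of the 3 values shown sit).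

Compound 4 `CCN(CC)CCCn1c(N)c(-c2nc3ccccc3[nH]2)c2nc(C#N)c(C#N)nc21` keeps the shared core and differs from compound 3 in one place, with diethylamino in place of dimethylamino on a saturated chain carbon, three bonds along the chain from an aromatic nitrogen.

Among the compounds with values here, no measured step makes this exact exchange. The nearest are an at least 40-fold lower number from compound 2 to compound 3 (1.60 log units; beyond the scatter), with dimethylamino in place of hydrogen, and an at least 40-fold lower number from compound 1 to compound 3 (1.60 log units; beyond the scatter), with (dimethylamino)methyl in place of pyrrolidin-1-yl. Both are large, so the number in this assay can move sharply with what stands at this end of the chain. Compound 4 still carries an amino group on the propyl chain, the change that goes with an at least 40-fold lower number from compound 2 to compound 3 (1.60 log units; beyond the scatter), so a step of that size is not expected. A modest move toward a higher number is expected instead, though a result at the limit remains possible.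

The expected step is a 2.0-fold higher number from compound 3 to compound 4 (0.31 log units; beyond the scatter).

For compound 4 the estimated value is 2500 nM, with an expected range from 600 nM to 20000 nM.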

Compound 4, half-maximal inhibitory concentration: 1870 nM
For compound 4 the middle estimate is 1.3-fold (0.13 log units) above the measured one; measured number inside the range.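

In this assay the exchange of dimethylamino for diethylamino on a saturated chain carbon, three bonds along the chain from an aromatic nitrogen, gives a 1.5-fold higher number from compound 3 to compound 4 (0.18 log units; within the scatter) and so the two compounds cannot be told apart, even though the entering group is the larger one by heavy atoms. The large gap to the compounds at the limit is therefore not tied to dimethylamino alone, for the 3-(diethylamino)propyl chain also gives an at least 26-fold lower number from compound 2 to compound 4 (1.42 log units; beyond the scatter) and an at least 26-fold lower number from compound 1 to compound 4 (1.42 log units; beyond the scatter) and thereby stands apart both from the plain propyl of compound 2 and from the shorter pyrrolidin-1-yl chain of compound 1. Both of these steps are bounds and not exact sizes, since compound 1 and compound 2 each rest on a limit: the limit of > 50000 nM in this assay, at which 2 of the 4 values shown sit.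

From the compounds shown here alone, whether a pyrrolidin-1-yl or morpholine ring at the end of the propyl chain would keep a value of this order stays open, and compound 1 cannot settle it, with its amine and its chain differing together. Also open, going by these compounds, is how a primary amine on the propyl chain, or dimethylamino on a longer chain such as butyl, would read.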